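From trifluoromethyl to nitro on the benzyl group

A few compounds are considered here, and "the series" means these few. Any claim that something is new, unique, unknown or untested is made for them only; others in the source may bear on it.

Compound 1 `C=C1C(=O)O[C@H]2[C@H]1CC/C(COC(=O)Cn1cc(F)c(=O)[nH]c1=O)=C\CC[C@@]1(C)O[C@@H]21`: > 20000 nM
Compound 2 `C=C1C(=O)O[C@H]2[C@H]1CC/C(COC(=O)Cn1cc(F)c(=O)n(Cc3ccc(C(F)(F)F)cc3)c1=O)=C\CC[C@@]1(C)O[C@@H]21`: 2250 nM
Compound 3 `C=C1C(=O)O[C@H]2[C@H]1CC/C(COC(=O)Cn1cc(F)c(=O)n(Cc3ccc([N+](=O)[O-])cc3)c1=O)=C\CC[C@@]1(C)O[C@@H]21`: not yet measured

In a functional assay on Bel7402/5-FU cells (Homo sapiens) for antiproliferative activity, read by MTT assay, with a stated time of 72 h (a lower number here means a stronger inhibitor, a higher number a weaker inhibitor), compound 1 reaches only a limit, > 20000 nM. Going by the values given here, compound 2 gives 2250 nM, the only actual number so far.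

Compound 3 keeps the core and the benzyl group of compound 2 but carries nitro in place of trifluoromethyl on an aromatic carbon, para to a large group: nitro in place of trifluoromethyl on an aromatic carbon.

Among the compounds with values here, only one measured step bears on this change. That step, an at least 8.8-fold lower number from compound 1 to compound 2 (0.94 log units; beyond the scatter), lies beyond the scatter and came with 4-(trifluoromethyl)benzyl in place of hydrogen on an aromatic nitrogen. It adds the whole group and does not compare one substituent on the ring with another, so it gives no direction for the present exchange. Since the benzyl group stays, compound 3 is expected to remain in the range of compound 2 at 2250 nM in this assay, with no change beyond the scatter. The expected change is a 1.1-fold higher number from compound 2 to compound 3 (0.05 log units; within the scatter). For compound 3 the estimated value is 2500 nM, with an expected range from 900 nM to 7000 nM.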

Compound 3, half-maximal inhibitory concentration: 4340 nM
For compound 3 the middle estimate is 1.7-fold (0.24 log units) below the measured one; low and high end bracket the measured number.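

In this assay, nitro in place of trifluoromethyl on an aromatic carbon, para to a large group, gives a 1.9-fold higher number from compound 2 to compound 3 (0.29 log units; within the scatter), so this assay does not separate the two substituents at this position. The gain from replacing the hydrogen on the aromatic nitrogen also appears with the second benzyl group, an at least 4.6-fold lower number from compound 1 to compound 3 (0.66 log units; beyond the scatter), so among the compounds shown it does not depend on trifluoromethyl alone. Compound 1 stands at a limit and not at a number, so the full size of the gain from either benzyl group cannot be stated: the limit of > 20000 nM in this assay, at which 1 of the 3 values shown sits.

What the compounds shown leave open is whether this tolerance extends to other groups at the same place, such as an amine, a methoxy group or a plain hydrogen on the benzyl ring. They also leave open whether the benzyl group itself is needed on the aromatic nitrogen, or whether a simple ethyl group or a longer alkyl chain would give a similar number in this assay.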